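A few compounds are considered here, and "the series" means these few. Any claim that something is new, unique, unknown or untested is made for them only; others in the source may bear on it.

For the measured compounds named here, compound 1 `CCOC(=O)C(=O)N(c1ccccc1)c1nccc(-c2ccncc2)n1` is the only compound here with an actual number: in a functional assay for inhibition, with Homo sapiens as the target (a higher number here means a weaker inhibitor, a lower number a stronger inhibitor), compound 1 gives 2200 nM. Compound 2 `COc1ccc(N(C)c2nccc(-c3cccnc3)n2)cc1` gives > 24000 nM in this assay, which is a limit of the assay rather than a number, a point where one of the two values sits (the limit of > 24000 nM in this assay, at which 1 of the 2 values shown sits). Compound 3 `c1ccc(Nc2nccc(-c3ccncc3)n2)cc1` has not been measured; it differs from compound 1 by hydrogen in place of (ethoxycarbonyl)carbonyl on a nitrogen on an aromatic ring. Going by the values given here, no measured pair shows what such a change does. The step from compound 1 to compound 3 is expected to be a 2.8-fold lower number from compound 1 to compound 3 (0.44 log units; beyond the scatter), toward stronger inhibition. Compound 3 is estimated at 800 nM, between 200 nM and 4000 nM.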

Compound 3, half-maximal inhibitory concentration: 900 nM
For compound 3 the middle estimate is 1.1-fold (0.05 log units) below the measured one; measured number inside the range.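

Putting hydrogen in place of (ethoxycarbonyl)carbonyl on this nitrogen gives a 2.4-fold lower number from compound 1 to compound 3 (0.39 log units; beyond the scatter) in this assay. For the compounds shown here, this is the first measured step at this position, and it shows that the (ethoxycarbonyl)carbonyl group is not required for inhibition here. Nothing measured here says why the number moves this way.

Going by these compounds, whether an acetyl group or a longer alkyl chain on this nitrogen would give a higher or lower number stays open. Going by these compounds alone, compound 2 differs from both other compounds in more than one place, so no step involving it can be read.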